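Opening a piperidine ether to an amino-propoxy chain

The compounds below may be only part of what the source reports. "The series", "measured", "known", "first", "only" and "open" are said of these compounds alone.

Measured compounds in an ADME assay on microsomes from liver (Homo sapiens) for metabolic stability, read by LC-MS, tested at 1 uM; a lower number here means slower removal, a higher number faster removal of the compound:
compound 1 `CC(C)(O)CN1CCC(Oc2ccc([C@H]3CC[C@]4(CC3)OOC3(O4)C4CC5CC(C4)CC3C5)cc2)CC1` gives 18 mL.min-1.g-1
compound 2 `O=S(=O)(c1ccc([C@H]2CC[C@]3(CC2)OOC2(O3)C3CC4CC(C3)CC2C4)cc1)N1CCNCC1` gives 16 mL.min-1.g-1
compound 3 `NCCOCCOc1ccc([C@H]2CC[C@]3(CC2)OOC2(O3)C3CC4CC(C3)CC2C4)cc1` gives < 7 mL.min-1.g-1, which is a limit of the assay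

Compound 1 and compound 2 cannot be separated on these numbers: a 1.1-fold lower number from compound 1 to compound 2 (0.05 log units; within the scatter). For compound 3 the number is a limit, (the limit of < 7 mL.min-1.g-1 in this assay, at which 1 of the 3 values shown sits), so it can only be said that compound 3 sits at or beyond that bound. The two steps that reach compound 3 are both beyond the scatter: an at least 2.5-fold lower number from compound 1 to compound 3 (0.41 log units; beyond the scatter) and an at least 2.2-fold lower number from compound 2 to compound 3 (0.35 log units; beyond the scatter).

Compound 4 `CC(C)(O)CNCCCOc1ccc([C@H]2CC[C@]3(CC2)OOC2(O3)C3CC4CC(C3)CC2C4)cc1` has not yet been measured in this assay. It differs from compound 1 by 3-((2-hydroxy-2-methylpropyl)amino)propyl in place of 1-(2-hydroxy-2-methylpropyl)piperidin-4-yl on an oxygen on an aromatic ring. Within the data shown here, the step that bears on it most directly is the one from compound 1 to compound 3, where a chain on the same oxygen also took the place of the piperidine group and gave an at least modest fall. The step from compound 2 to compound 3 points the same way. A lower number than compound 1 is therefore expected, of modest size, with the reading possibly reaching the limit.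

Compound 4 is expected to give 10 mL.min-1.g-1, between 5 mL.min-1.g-1 and 20 mL.min-1.g-1. The expected step is a 1.8-fold lower number from compound 1 to compound 4 (0.26 log units; within the scatter).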

Compound 4, intrinsic clearance in microsomes: 8 mL.min-1.g-1
For compound 4 the middle estimate is 1.3-fold (0.10 log units) above the measured one; measured number inside the range.
By their numbers in this assay, from the lowest: compounds 4, 2 and 1 (each within the scatter of the next, the first and the last beyond it). At a limit, below all of these: compound 3.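

In this assay, the open 3-((2-hydroxy-2-methylpropyl)amino)propyl chain on the same oxygen gives a 2.3-fold lower number from compound 1 to compound 4 (0.35 log units; beyond the scatter), and here the 2-hydroxy-2-methylpropyl end stays in place, so a lower number than that of compound 1 does not depend on losing this end, as the earlier change to the 2-(2-aminoethoxy)ethyl chain left unresolved. The gain is not shown against the sulfonyl series member: a 2.0-fold lower number from compound 2 to compound 4 (0.30 log units; within the scatter). The remaining step, an at least 1.1-fold higher number from compound 3 to compound 4 (0.05 log units; that floor lies within the scatter), starts from a limit of the assay and does not separate the two chains: the limit of < 7 mL.min-1.g-1 in this assay, at which 1 of the 4 values shown sits.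

Left open is whether the 2-hydroxy-2-methylpropyl end matters at all, which a plain primary amine on the same propyl chain would test, and whether the step follows from the opened ring or from the chain itself, which a pyrrolidine or a longer chain on that oxygen would help to separate. Also open, going by these compounds, is how a methyl group on the chain nitrogen would read in this assay.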